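The compounds below may be only part of what the source reports. "The series", "measured", "known", "first", "only" and "open" are said of these compounds alone.

Compound 1, `Cc1ccc(-c2csc(NC(=O)COc3ccccc3)n2)cc1`, is the starting point of this small set. In a functional assay on A549 cells (Homo sapiens) for cytotoxicity, read by trypan blue exclusion, with a stated time of 48 h (a lower number here means a stronger inhibitor, a higher number a weaker inhibitor), compound 1 gives 41100 nM. Compound 2, `Cc1ccc(-c2csc(NC(=O)COc3ccccc3C)n2)cc1`, carries the change (methyl in place of hydrogen on an aromatic carbon), and in this assay compound 2 gives 50100 nM; the step is a 1.2-fold higher number from compound 1 to compound 2 (0.09 log units; within the scatter). Compound 3, `O=C(COc1ccccc1)Nc1nc(-c2ccc(Cl)cc2)cs1`, differs from compound 1 by chloro in place of methyl on an aromatic carbon, and in this assay compound 3 gives 42800 nM, a step of a 1.0-fold higher number from compound 1 to compound 3 (0.02 log units; within the scatter). Compound 4, `Cc1ccccc1OCC(=O)Nc1nc(-c2ccc(Cl)cc2)cs1`, is not yet measured; it is made from compound 3 by methyl in place of hydrogen on an aromatic carbon, the same change that turns compound 1 into compound 2, set on cores that differ by chloro in place of methyl on an aromatic carbon. The step from compound 3 to compound 4 is expected to be a 1.2-fold higher number from compound 3 to compound 4 (0.08 log units; within the scatter), resting on a 1.2-fold higher number from compound 1 to compound 2 (0.09 log units; within the scatter) seen between compound 1 and compound 2. For compound 4 a value of 52000 nM is estimated, between 30000 nM and 90000 nM.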

Compound 4, half-maximal inhibitory concentration: 64800 nM
Beside the measured number, compound 4's estimate is 1.2-fold (0.10 log units) below it; the measured number falls inside the stated range.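

In this assay, the change from phenoxy to 2-methylphenoxy gives a 1.5-fold higher number from compound 3 to compound 4 (0.18 log units; within the scatter), and this step agrees with the earlier one on the other core: the same change on two cores in this assay, a 1.2-fold higher number (0.09 log units; within the scatter) from compound 1 to compound 2 and a 1.5-fold higher number (0.18 log units; within the scatter) from compound 3 to compound 4, 1.2-fold (0.09 log units) apart, within the scatter of two such steps. The chloro change on the methylated core gives a 1.3-fold higher number from compound 2 to compound 4 (0.11 log units; within the scatter), and it agrees with its earlier step in the same way: the same change on two cores in this assay, a 1.0-fold higher number (0.02 log units; within the scatter) from compound 1 to compound 3 and a 1.3-fold higher number (0.11 log units; within the scatter) from compound 2 to compound 4, 1.2-fold (0.09 log units) apart, within the scatter of two such steps. Among the compounds shown here, all these steps lie within the scatter, so the series shows only that neither change moves the number readably on either core; it does not show how a change with a readable effect would carry from one core to another.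

The compounds shown leave open whether an amine or a carboxylic acid in place of the methyl would give a larger step. The same holds for a longer chain.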